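Solubility of a Spirocyclic Urea: Isoxazole Amide Replaces Chloropyridine

The source may hold more compounds than are shown below. What is called first, only, known or untested is meant among the compounds shown, and "the series" means these compounds.

Compound 1 `O=C(Nc1ccc(OC(F)(F)F)cc1)N1CCOC2(CCN(C(=O)c3cc(Cl)ccn3)CC2)C1` gives 89 ug/mL.
Compound 2 `O=C(Nc1ccc(C(F)(F)F)cc1)N1CCOC2(CCN(C(=O)c3ccccc3)CC2)C1` gives 63 ug/mL.
Compound 3 `O=C(Nc1ccc(C(F)(F)F)cc1)N1CCOC2(CCN(C(=O)c3ccccc3Cl)CC2)C1` gives 12 ug/mL.

In an ADME assay for solubility, in simulated intestinal fluid (on this read-out higher numbers stand for higher solubility and lower numbers for lower solubility), compound 1 and compound 2 lie within the scatter of each other, while compound 3 lies beyond the scatter below both. Within the data shown here, the one step that isolates a single change is a 5.3-fold lower number from compound 2 to compound 3 (0.72 log units; beyond the scatter). Compound 4 `Cc1cc(C(=O)N2CCC3(CC2)CN(C(=O)Nc2ccc(OC(F)(F)F)cc2)CCO3)no1` has not yet been measured. It differs from compound 1 by 5-methyl-1,2-oxazol-3-yl in place of 4-chloropyridin-2-yl on a carbonyl carbon. The step from compound 2 to compound 3 bears on this only in part: there a chloro entered and the number fell, whereas here the group that leaves carries a chlorine and the group that enters carries none. Among the measured compounds shown here, no measured pair mirrors the exchange of the ring itself, so the size of that part is unknown. A number for compound 4 that is not lower than that of compound 1, and perhaps somewhat higher, is therefore expected, a step of a 1.6-fold higher number from compound 1 to compound 4 (0.20 log units; within the scatter). The estimate for compound 4 is 140 ug/mL, within 60 ug/mL to 320 ug/mL.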

Compound 4, solubility: 83 ug/mL
Estimate against measurement, compound 4: 1.7-fold (0.23 log units) above, and the stated range covers the measured number.
By their numbers in this assay, from the lowest: compound 3; then compounds 2, 4 and 1 (each within the scatter of the next).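

In this assay, the carbonyl carbon of the core of compound 1 accepts a five-membered aromatic ring with 2 hetero atoms in place of a six-membered one with 1 hetero atom, with a 1.1-fold lower number from compound 1 to compound 4 (0.03 log units; within the scatter). The earlier step with a chloro, a 5.3-fold lower number from compound 2 to compound 3 (0.72 log units; beyond the scatter), involved a change on a phenyl ring, whereas here a chlorine-free group replaces a chlorine-bearing one and the two numbers remain within the scatter of each other. Nothing shown gives a reason for this outcome.

Going by these compounds, because the ring and its substituents change together here, the separate contributions of the chlorine, the methyl and the ring itself remain open. On these data alone, it is also open how the number would respond to a group of another kind on this carbonyl carbon, such as a ring bearing a carboxylic acid or an amine.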